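Amino in place of chloro: one change from compound 1

The compounds below may be only part of what the source reports. "The series", "measured", "known", "first", "only" and "open" are said of these compounds alone.

Measured so far in a functional assay on HCT-15 cells (Homo sapiens) for cytotoxicity, read by sulforhodamine B assay, with a stated time of 48 h; on this read-out higher numbers stand for weaker inhibition of growth and lower numbers for stronger inhibition of growth:
compound 1 `ClCc1cccc(Cn2cnc3c(Cl)nc(Cl)nc32)c1` gives 6910 nM
compound 2 `ClCc1cccc(Cn2cnc3nc(Cl)nc(Cl)c32)c1` gives 2130 nM
compound 3 `ClCc1ccccc1Cn1cnc2ncnc(Cl)c21` gives 2880 nM

Compound 1 carries the highest number of the three. Compound 3 stands nearest to it, with a lower number beyond the usual scatter; compound 2 stands furthest, also with a lower number beyond the scatter. No pair among these three differs in only one place, so no single step between measured compounds can be read off.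

Compound 4 `Nc1nc(Cl)c2ncn(Cc3cccc(CCl)c3)c2n1` has not yet been measured in this assay. Against compound 1 the change is amino in place of chloro on an aromatic carbon, on the aromatic carbon between two ring nitrogen atoms, meta to a chloro group, meta and para to a fused ring. Among the measured compounds shown here, with no measured step of this kind to guide the size, the step is expected to be modest, a 1.3-fold higher number from compound 1 to compound 4 (0.11 log units; within the scatter), towards a higher number or none beyond the scatter. Compound 4 is therefore expected to give about 9000 nM, with a range of 3000 nM to 30000 nM.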

Compound 4, concentration for total growth inhibition: 6760 nM
Beside the measured number, compound 4's estimate is 1.3-fold (0.12 log units) above it; measured number inside the range.
By their numbers in this assay, from the lowest: compounds 2 and 3 (each within the scatter of the next); then compounds 4 and 1 (each within the scatter of the next).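

In this assay, among the compounds shown here, the step of amino in place of chloro on the aromatic carbon between two ring nitrogen atoms is a 1.0-fold lower number from compound 1 to compound 4 (0.01 log units; within the scatter) and gives the first one-place reading. At this position, on the core of compound 1, chloro is therefore not required to hold the number, and an added hydrogen-bond donor leaves it within the scatter. Nothing available explains this match.

On these data alone, whether a methylamino, hydroxyl or methoxy group here would behave the same stays open. This single step also cannot say whether amino would be tolerated on other cores in the series.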